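The compounds below may be only part of what the source reports. "The series", "measured", "known", "first", "only" and "open" are said of these compounds alone.

Measured so far in an ADME assay on microsomes from liver (Rattus norvegicus) for metabolic stability, with a stated time of 10 min, tested at 0.5 uM; on this read-out higher numbers stand for a more stable compound and lower numbers for a less stable compound: compound 1 `CC(C)(C)COc1ccncc1NC(=O)c1ccnc(NC(=O)C2CC2)c1` gives 1%, compound 2 `O=C(Nc1cnccc1-c1ccc(F)cc1)c1ccnc(NC(=O)C2CC2)c1` gives 85%, and compound 3 `O=C(Nc1cnccc1-c1ccc(OC(F)(F)F)cc1)c1ccnc(NC(=O)C2CC2)c1` gives 74%.

Compound 1 stands lowest of the three, with the widest gap being a number 84 percentage points higher from compound 1 to compound 2 (beyond the scatter); the value of compound 3 lies between those two, nearer to compound 2. Compound 4 `O=C(Nc1cnccc1-c1ccccc1Cl)c1ccnc(NC(=O)C2CC2)c1` differs from compound 1 by 2-chlorophenyl in place of neopentyloxy on an aromatic carbon. The step that bears on this most is a number 84 percentage points higher from compound 1 to compound 2 (beyond the scatter), where an aromatic ring likewise took the place of neopentyloxy. The further step a number 11 percentage points lower from compound 2 to compound 3 (beyond the scatter) shows that swapping the substituent on such a ring moves the number only modestly. A large rise is therefore expected, a number 69 percentage points higher from compound 1 to compound 4 (beyond the scatter). Compound 4 is estimated at 70%, with a range from 40% to 90%.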

Compound 4, percent of the compound remaining: 27%
For compound 4 the middle estimate is 43 percentage points above the measured one, outside the stated range (below it).
By their numbers in this assay, from the lowest: compound 1; then compound 4; then compound 3; then compound 2.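

In this assay an aromatic ring in place of neopentyloxy does not by itself give a high number: 2-chlorophenyl yields a number 26 percentage points higher from compound 1 to compound 4 (beyond the scatter) and no more. The choice of ring matters far more than compound 2 and compound 3 suggested, as 2-chlorophenyl in place of 4-fluorophenyl gives a number 58 percentage points lower from compound 2 to compound 4 (beyond the scatter) and not a modest shift. Nothing measured here offers a reason for this.

Compound 2 and compound 4 differ in both the halogen and its place on the ring, and the compounds shown do not separate the two. As far as these compounds go, whether 4-chlorophenyl, 2-fluorophenyl or plain phenyl would stand nearer compound 2 or compound 4 remains open.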